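Swapping the charged ring on a seven-carbon chain

The source may hold more compounds than are shown below. What is called first, only, known or untested is meant among the compounds shown, and "the series" means these compounds.

Measured compounds:
compound 1 `Cc1cc(OCCCCCCC[n+]2ccccc2)cc(-n2cc(C(=O)Nc3cc(F)cc(F)c3)c(=O)c3ccc(N(C)C)nc32)c1` gives 7.7%
compound 2 `CC[N+]1(CCCCCCCOc2cc(C)cc(-n3cc(C(=O)Nc4cc(F)cc(F)c4)c(=O)c4ccc(N(C)C)nc43)c2)CCCCC1` gives 67.2%
compound 3 `Cc1cc(OCCCCCCC[N+]2(C)CCN(C)CC2)cc(-n2cc(C(=O)Nc3cc(F)cc(F)c3)c(=O)c3ccc(N(C)C)nc32)c1` gives 2.8%

All three were tested in an assay on LX2 cells for inhibition of COL1A1 promoter (Homo sapiens), read by a luciferase reporter, with a stated time of 24 h, tested at 20 uM; a higher number here means a stronger effect of the compound at the concentration tested, a lower number a weaker effect. Compound 3 gives the lowest of the three numbers in this assay, but its step of a number 4.9 percentage points lower from compound 1 to compound 3 (within the scatter) is within the scatter, so compounds 1 and 3 cannot be told apart. Compound 2 stands clearly apart: a number 59.5 percentage points higher from compound 1 to compound 2 (beyond the scatter) and a number 64.4 percentage points lower from compound 2 to compound 3 (beyond the scatter) are both large.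

Compound 4 `Cc1cc(OCCCCCCC[N+](C)(C)C2CCCCC2)cc(-n2cc(C(=O)Nc3cc(F)cc(F)c3)c(=O)c3ccc(N(C)C)nc32)c1` has not yet been measured. It differs from compound 3 in one place: a group of 9 heavy atoms (8 carbon, 1 nitrogen; one six-membered non-aromatic ring of carbon only) in place of a group of 8 heavy atoms (6 carbon, 2 nitrogen; one six-membered non-aromatic ring with 2 hetero atoms), on a saturated chain carbon, seven bonds along the chain from an oxygen on an aromatic ring

The step that bears on this change is a number 64.4 percentage points lower from compound 2 to compound 3 (beyond the scatter), where a six-membered non-aromatic ring with one hetero atom was replaced by one with two hetero atoms and the number fell sharply. Compound 4 goes the other way, back to a charged nitrogen with no second hetero atom in the ring, so a large rise is expected for it in this assay, on the order of a number 47.2 percentage points higher from compound 3 to compound 4 (beyond the scatter). Within the data shown here, with only one comparable step, the estimate for compound 4 is 50%, with a range from 20% to 75%.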

Compound 4, a percentage reported as inhibition, at one concentration (the size of the read-out at that concentration, not a potency): 52.5%
The estimate for compound 4 lay 2.5 percentage points below the measured number; the range from low to high includes it.
By their numbers in this assay, from the lowest: compounds 3 and 1 (each within the scatter of the next); then compound 4; then compound 2.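

In this assay the six-membered non-aromatic ring of carbon only gives a high number, with a number 49.7 percentage points higher from compound 3 to compound 4 (beyond the scatter) and a number 44.8 percentage points higher from compound 1 to compound 4 (beyond the scatter) as well, so at this chain end a strong read-out is no longer confined to compound 2. The two are still distinct, with a number 14.7 percentage points lower from compound 2 to compound 4 (beyond the scatter) modest but beyond the scatter, and among these four compounds the pyridinium and the ring with 2 hetero atoms stay the low pair. Nothing given here accounts for these differences.

The compounds shown leave open how an uncharged piperidine or an open-chain trimethylammonium group would read on this saturated chain carbon, and whether a shorter or longer chain would keep the high numbers. From the compounds shown here alone, these are readings at one concentration, so the potency of compound 2 and compound 4 also remains open.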